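A few compounds are considered here, and "the series" means these few. Any claim that something is new, unique, unknown or untested is made for them only; others in the source may bear on it.

Measured so far in an assay on isolated protein for binding affinity to sphingosine 1-phosphate receptor 2 (Homo sapiens), read by surface plasmon resonance; on this read-out higher numbers stand for weaker binding and lower numbers for tighter binding:

- compound 1, `Cc1nn(C)c2nc(NNC(=O)Nc3cc(Cl)nc(Cl)c3)cc(-c3ccc(Cl)s3)c12`: 1980 nM
- compound 2, `CCCOc1cc(NC(=O)NNc2cc(-c3ccc(OC)cc3)c3cnn(C)c3n2)cc(Cl)n1`: 3140 nM

Two compounds of the series carry a number in this assay. Compound 1 gives 1980 nM and compound 2 gives 3140 nM; the two values fall within the scatter of each other, so compound 1 cannot be separated from compound 2 on these numbers. Going by the values given here, no pair of measured compounds differs in one place, so the series holds no step from which a change at a single position could be read.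

The next compound, compound 3 `Cc1nn(C)c2nc(NNC(=O)Nc3cc(Cl)nc(Cl)c3)cc(-c3ccccc3)c12`, departs from compound 1 by one change: phenyl in place of 5-chlorothiophen-2-yl on an aromatic carbon

Nothing measured here speaks to this exchange. The expectation therefore rests on the value of compound 1 alone, and the step is expected to stay within the scatter, perhaps leaning toward a somewhat higher number. For compound 3 the estimate in this assay is 3000 nM, with a range from 1000 nM to 9000 nM. The expected step from compound 1 to compound 3 is a 1.5-fold higher number from compound 1 to compound 3 (0.18 log units; within the scatter).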

Compound 3, dissociation constant: 5320 nM
The estimate for compound 3 lay 1.8-fold (0.25 log units) below the measured number; the range from low to high includes it.
By their numbers in this assay, from the lowest: compounds 1, 2 and 3 (each within the scatter of the next, the first and the last beyond it).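

In this assay, going by these compounds alone, the exchange gives the first single-place step (a 2.7-fold higher number from compound 1 to compound 3 (0.43 log units; beyond the scatter)): the read-out responds to the group on this aromatic carbon, and the move, though modest, runs toward weaker binding on leaving 5-chlorothiophen-2-yl for phenyl. Both groups have the same count of heavy atoms, so the step comes without a change in that count, while ring size, the sulfur, the chlorine and the hydrogen-bond acceptor count all change at once, and this single pair cannot separate them. Nothing measured on these compounds accounts for the shift in the number.

Open, from the compounds shown here alone, is whether the step follows the ring or its chlorine; an unsubstituted thiophen-2-yl and a 4-chlorophenyl at this position on the core of compound 1 would pull those two apart. Also open, going by these compounds, is how far this position tolerates other kinds of group, such as a pyridyl ring, an amine or a carboxylic acid, since only aromatic rings appear here.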